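Swapping 4-Cyanophenyl for Pyridin-2-yl: Cytotoxicity Outlook

A few compounds are considered here, and "the series" means these few. Any claim that something is new, unique, unknown or untested is made for them only; others in the source may bear on it.

Compound 1, `CCOc1cc(C)nn1-c1nc(C(F)(F)F)cc(=O)[nH]1`: in an ADME assay on CHO cells (Cricetulus griseus) for cytotoxicity, read by MTT assay (on this read-out lower numbers stand for stronger inhibition and higher numbers for weaker inhibition), compound 1 gives > 50000 nM, which is a limit of the assay rather than a number.
Compound 2, `Cc1cc(Nc2ccc(C#N)cc2)n(-c2nc(C(F)(F)F)cc(=O)[nH]2)n1`: in this assay compound 2 gives 20000 nM.

Compound 1 therefore sits at the limit of > 50000 nM in this assay, at which 1 of the 2 values shown sits. For the measured compounds named here, compound 2 stands as the only true number measured in this assay, so no step between two numbers is available for comparison.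

Compound 3, `Cc1cc(Nc2ccccn2)n(-c2nc(C(F)(F)F)cc(=O)[nH]2)n1`, has not yet been measured. It differs from compound 2 in one place: pyridin-2-yl in place of 4-cyanophenyl on a nitrogen on an aromatic ring. Going by the values given here, with no measured step to lean on, the expected change in this assay is small, most likely within the usual scatter, and if anything tending toward weaker inhibition. Compound 3 is expected to give about 30000 nM in this assay, estimated to lie between 10000 nM and 90000 nM. The estimated shift from compound 2 to compound 3 is a 1.5-fold higher number from compound 2 to compound 3 (0.18 log units; within the scatter).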

Compound 3, half-maximal inhibitory concentration: 23000 nM
Compound 3: the middle estimate sits 1.3-fold (0.12 log units) above what was measured; measured number inside the range.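

In this assay, for the compounds shown here, pyridin-2-yl in place of 4-cyanophenyl on a nitrogen on an aromatic ring gives the first step between two true numbers: a 1.2-fold higher number from compound 2 to compound 3 (0.06 log units; within the scatter). At this level of cytotoxicity, compound 2 and compound 3 cannot be told apart, so at this position neither the nitrile nor the ring of carbon only is needed to keep a measurable value. On these data alone, a second comparison, (pyridin-2-yl)amino in place of ethoxy on an aromatic carbon, gives an at least 2.1-fold lower number from compound 1 to compound 3 (0.33 log units; beyond the scatter), and its full size stays unknown since compound 1 stands at a limit: the limit of > 50000 nM in this assay, at which 1 of the 3 values shown sits.

Still open, as far as these compounds go, is whether a butylamino chain or a morpholine on that aromatic carbon would give a value like that of compound 3. Equally open, from the compounds shown here alone, is what a carboxylic acid on the pyridine ring would do in this assay.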